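The source may report more compounds than this note shows. Statements on the series, on what has been measured and on what is new or still open speak of the compounds shown alone.

Compounds measured so far:
compound 1, `COc1ccccc1/C=C/C(=O)c1ccc(OCC(=O)N[C@H]2CCOC2=O)cc1` — > 64000 nM (a limit)
compound 2, `C=CCc1ccc(OCCSC(=S)N[C@H]2CCOC2=O)c(OC)c1` — > 64000 nM (a limit)

In a functional assay on MCF7 cells (Homo sapiens) for antiproliferative activity, read by MTT assay, with a stated time of 72 h (on this read-out lower numbers stand for stronger inhibition and higher numbers for weaker inhibition), compound 1 gives > 64000 nM, which is a limit of the assay rather than a number. Compound 2 likewise gives > 64000 nM in this assay, again a limit. the limit of > 64000 nM in this assay, at which 2 of the 2 values shown sit, describes the whole picture so far. Compound 3, `O=C(COc1ccc(C(=O)/C=C/c2ccc(Br)cc2)cc1)N[C@H]1CCOC1=O`, differs from compound 1 by 4-bromophenyl in place of 2-methoxyphenyl on a double-bonded chain carbon bound to a double-bonded chain carbon. For the measured compounds named here, no measured step exists for this pair. The step that the limit leaves unreadable from compound 1 to compound 3 is expected to be none beyond the scatter. Compound 3 is therefore estimated at 80000 nM, with a range from 20000 nM to 300000 nM, and a limit is again the likeliest outcome.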

Compound 3, half-maximal inhibitory concentration: > 64000 nM
Compound 3 gave a limit, no number; the forecaster's own chance of this, stated with the estimate: 75%; the middle value lies beyond the limit too.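

For the compounds shown here, compound 1 and compound 3 both give a limit rather than a number, so no step between them can be read. The compounds shown leave open what, if anything, would bring a measurable value in this series.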